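Longer chain, carbonate in place of methoxy: compound 4

This account rests on a few compounds, and the source may have more. Where it says the series, first, only, none or still open, it means among the compounds named here.

Three compounds share one core. Compound 1 `CCCCCC[C@@]1(C)SC(=O)C=C1OC` gives 14 ug/mL in a functional assay on MCF7 cells (Homo sapiens) for inhibition; a higher number here means a weaker inhibitor, a lower number a stronger inhibitor. Compound 3 `C#CCOC1=CC(=O)S[C@]1(C)CCCCCC` gives 21.9 ug/mL; the step of a 1.6-fold higher number from compound 1 to compound 3 (0.19 log units; within the scatter) stays within the scatter. As far as these compounds go, compound 2 `CCCCCCCC[C@@]1(C)SC(=O)C=C1OC` reports only a limit, > 50 ug/mL, so it sits at the limit of > 50 ug/mL in this assay, at which 1 of the 3 values shown sits, and its true value is unknown. The step of an at least 3.5-fold higher number from compound 1 to compound 2 (0.55 log units; beyond the scatter) is beyond the scatter.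

Compound 4 `CCCCCCCC[C@@]1(C)SC(=O)C=C1OC(=O)OCC` differs from compound 2 by ethoxycarbonyl in place of methyl on an oxygen on an unsaturated carbon. Among the measured compounds shown here, the only comparable change on that oxygen, from compound 1 to compound 3, was within the scatter, so no shift beyond the scatter is expected, and compound 4 is expected to remain weak, at 60 ug/mL between 20 ug/mL and 200 ug/mL, the expected step being a step that the limit leaves unreadable from compound 2 to compound 4.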

Compound 4, half-maximal inhibitory concentration: 14.5 ug/mL
Beside the measured number, compound 4's estimate is 4.1-fold (0.62 log units) above it; measured number below the stated range.
By their numbers in this assay, from the lowest: compounds 1, 4 and 3 (each within the scatter of the next). At a limit, above all of these: compound 2.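

On the oxygen on an unsaturated carbon, ethoxycarbonyl in place of methyl gives, in this assay, an at least 3.4-fold lower number from compound 2 to compound 4 (0.53 log units; beyond the scatter), whereas the earlier change on that oxygen, a 1.6-fold higher number from compound 1 to compound 3 (0.19 log units; within the scatter), stayed within the scatter. With the longer chain, then, the group on this oxygen can shift the number beyond the scatter. The true size of the step cannot be read, since compound 2 stands at a limit: the limit of > 50 ug/mL in this assay, at which 1 of the 4 values shown sits.

Open, as far as these compounds go, is whether ethoxycarbonyl gives a similar step on the shorter chain of compound 1. Also open, from the compounds shown here alone, is how an acetyl group or a carbamate on that oxygen would read.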